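Swapping the anilino group for a furanylmethyl amine

The source may hold more compounds than are shown below. What is called first, only, known or untested is meant among the compounds shown, and "the series" means these compounds.

Of the compounds shown here, two sharing one core have been measured in an assay on cells for inhibition of serine/threonine-protein kinase WNK1 (Homo sapiens), read by scintillation counting and 33P incorporation, with a stated time of 30 min; a lower number here means a stronger inhibitor, a higher number a weaker inhibitor. Compound 1 `O=[N+]([O-])c1cc(S(=O)(=O)C(Cl)(Cl)Br)ccc1NC1CCCCC1` gives 1600 nM. Compound 2 `O=[N+]([O-])c1cc(S(=O)(=O)C(Cl)(Cl)Br)ccc1Nc1ccccc1` gives 7200 nM. Among the compounds with values here, compound 2 therefore holds the highest number of the two, and the only step, a 4.5-fold higher number from compound 1 to compound 2 (0.65 log units; beyond the scatter), is modest but beyond the scatter. Compound 3 `O=[N+]([O-])c1cc(S(=O)(=O)C(Cl)(Cl)Br)ccc1NCc1ccco1` is the next compound, and it differs from compound 2 by (furan-2-yl)methyl in place of phenyl on a nitrogen on an aromatic ring. Within the data shown here, the one measured step that bears on this change is the exchange of cyclohexyl for phenyl at the same nitrogen, which raised the number modestly from compound 1 to compound 2; the new (furan-2-yl)methyl group has neither of those two rings, so the direction is uncertain. On balance a modest reversal of that step is expected, estimated as a 2.4-fold lower number from compound 2 to compound 3 (0.38 log units; beyond the scatter). Compound 3 is expected to give about 3000 nM, within a range from 1000 nM to 9000 nM.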

Compound 3, half-maximal inhibitory concentration: 5000 nM
Estimate against measurement, compound 3: 1.7-fold (0.22 log units) below, within the range that was stated.
By their numbers in this assay, from the lowest: compound 1; then compounds 3 and 2 (each within the scatter of the next).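

In this assay, putting (furan-2-yl)methyl where phenyl stood gives a 1.4-fold lower number from compound 2 to compound 3 (0.16 log units; within the scatter), so at this nitrogen the two groups cannot be told apart, even though they differ in ring size and the furan ring brings an oxygen. Set against cyclohexyl, the same group gives a 3.1-fold higher number from compound 1 to compound 3 (0.49 log units; beyond the scatter), which leaves compound 1, the only one of the three without an aromatic ring on this nitrogen, with the lowest number. No measurement shown explains why the numbers fall this way.

On these data alone, whether the lower number goes with the saturated ring or with some other feature of cyclohexyl remains open. A cyclopentyl ring, a cyclohexylmethyl group or a plain butyl chain on this nitrogen would help separate these possibilities.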